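This account rests on a few compounds, and the source may have more. Where it says the series, first, only, none or still open, it means among the compounds named here.

Compound 1 `N#Cc1cnc(NCc2cnccc2C(F)(F)F)cc1N[C@H]1CC[C@H](O)CC1` stands lowest of the two numbers in an ADME assay on S9 fraction from liver (Homo sapiens) for metabolic stability, with a stated time of 1 h (a lower number here means that less of the compound is left, a higher number that more of the compound is left), where compound 1 gives 30%. Compound 2 `N#Cc1cnc(NCc2cnccc2C(F)(F)F)cc1NC1CCOCC1` gives 91% in this assay, a step of a number 61 percentage points higher from compound 1 to compound 2 (beyond the scatter). Compound 3 `N#Cc1cnc(NCc2cnccc2C(F)(F)F)cc1NCCC1CCOCC1` differs from compound 1 by 2-(oxan-4-yl)ethyl in place of 4-hydroxycyclohexyl on a nitrogen on an aromatic ring. Among the measured compounds shown here, the measured step from compound 1 to compound 2, in which oxan-4-yl also enters, bears on this change and was large; no measured step covers the 2-(oxan-4-yl)ethyl chain itself. A rise beyond the scatter is therefore expected, estimated as a number 42 percentage points higher from compound 1 to compound 3 (beyond the scatter). Compound 3 is estimated at 72%, between 45% and 95%.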

Compound 3, percent of the compound remaining: 23%
Compound 3: middle estimate off by 49 percentage points, on the high side; the whole stated range lies above it.
By their numbers in this assay, from the lowest: compounds 3 and 1 (each within the scatter of the next); then compound 2.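

In this assay the oxan-4-yl ring alone does not secure a high number: lengthening its attachment to 2-(oxan-4-yl)ethyl gives a number 68 percentage points lower from compound 2 to compound 3 (beyond the scatter) and removes the gain seen earlier. Against the hydroxylated ring, the same group gives a number 7 percentage points lower from compound 1 to compound 3 (within the scatter) and so shows no separation from it. At this nitrogen, how the ring is attached therefore matters as well as which ring is present, and nothing available here accounts for this. Going by these compounds, whether a shorter chain, as in oxan-4-ylmethyl, would fall with compound 2 or compound 3 remains open. So does the outcome with an amine in the ring, as in piperidin-4-yl.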